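Swapping tert-butyl for bromo in a slow-crossing compound

The source may hold more compounds than are shown below. What is called first, only, known or untested is meant among the compounds shown, and "the series" means these compounds.

Compound 1 `CNC(=O)c1cc(Oc2ccc3nc(Nc4cccc(C(C)(C)C)c4)ncc3c2)ccn1` is tested in an ADME assay on Caco-2 cells (Homo sapiens) for permeability, in the apical to basolateral direction (a lower number here means that the compound crosses the layer more slowly, a higher number that the compound crosses the layer faster), where compound 1 gives only a limit of the assay, < 1 10^-6 cm/s. Compound 2 `CNC(=O)c1cc(Oc2ccc3nc(Nc4cccc(C(C)(C)C)c4)ccc3c2)ccn1` likewise returns a limit in this assay, < 1 10^-6 cm/s. Among the measured compounds shown here, both results rest at the limit of < 1 10^-6 cm/s in this assay, at which 2 of the 2 values shown sit, so no measured step between compounds is available. Compound 3 `CNC(=O)c1cc(Oc2ccc3nc(Nc4cccc(Br)c4)ncc3c2)ccn1` differs from compound 1 by bromo in place of tert-butyl on an aromatic carbon. With only limits known, no step beyond the scatter can be expected. Compound 3 is expected to give about 1 10^-6 cm/s in this assay, within 0.3 10^-6 cm/s to 3 10^-6 cm/s. The expected step is a number no lower from compound 1 to compound 3 (the limit leaves the size open), within the usual scatter.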

Compound 3, apparent permeability: < 1 10^-6 cm/s
Compound 3 gave a limit, no number; the forecaster's own chance of this, stated with the estimate: 60%; the middle value lies on the limit itself.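

No step can be read from compound 1 to compound 3, because both results are limits and not numbers: the limit of < 1 10^-6 cm/s in this assay, at which 3 of the 3 values shown sit.

The compounds shown leave open how fast each one really crosses the layer, and whether swapping tert-butyl for bromo changes that at all.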